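Carbamate for hydroxyacetyl on the piperidine nitrogen

The source may report more compounds than this note shows. Statements on the series, on what has been measured and on what is new or still open speak of the compounds shown alone.

Of the compounds shown here, three have been measured in an assay on L1.2 cells for binding affinity to C-C chemokine receptor type 8 (Homo sapiens); a higher number here means a weaker inhibitor, a lower number a stronger inhibitor. For the measured compounds named here, compound 1 `CCOC(=O)N1CCC(NS(=O)(=O)c2ccc(NC(=O)c3ccccc3)c3ccccc23)CC1` gives 0.17 nM, and compound 2 `CCOC(=O)N1CCC(NS(=O)(=O)c2ccc(OC(=O)c3ccccc3)c3ccccc23)CC1` gives 16.4 nM; the one step between them, a 96-fold higher number from compound 1 to compound 2 (1.98 log units; beyond the scatter), is the only single-point change in the set. Compound 3 `Cc1ccccc1C(=O)Nc1ccc(S(=O)(=O)NC2CCN(C(=O)CO)CC2)c2ccccc12` gives 5.4 nM, which is the second highest of the three numbers, above compound 1 and below compound 2.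

Compound 4 `CNC(=O)N1CCC(NS(=O)(=O)c2ccc(NC(=O)c3ccccc3C)c3ccccc23)CC1` differs from compound 3 in one place: methylamino in place of hydroxymethyl on a carbonyl carbon. Going by the values given here, no measured step touches this position, since the step from compound 1 to compound 2 concerns the substituent on the aromatic carbon and not the group on the ring amide nitrogen. Compound 1, which carries an ethoxycarbonyl on that nitrogen, differs from compound 3 in two places, so its value can only be set beside that of compound 3 and not turned into a step. With nothing to lean on, the expected step of a 1.5-fold lower number from compound 3 to compound 4 (0.19 log units; within the scatter) is small, and compound 4 is estimated at 3.5 nM, with a range from 1 nM to 12 nM in this assay.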

Compound 4, inhibition constant: 0.7 nM
Beside the measured number, compound 4's estimate is 5.0-fold (0.70 log units) above it; measured number outside the range, below it.
By their numbers in this assay, from the lowest: compound 1; then compound 4; then compound 3; then compound 2.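

For the compounds shown here, the step of a 7.7-fold lower number from compound 3 to compound 4 (0.89 log units; beyond the scatter) in this assay is the first measured change at the group on a carbonyl carbon whose other neighbour is the amide-type nitrogen in a ring, and it lies beyond the scatter, so the number in this assay responds to what stands at this position. The exchange is close in what is counted: hydroxymethyl and methylamino each have 2 heavy atoms, 1 hydrogen-bond donor and no net charge, and hydroxymethyl alone has 1 hydrogen-bond acceptor. No evidence at hand accounts for this difference.

On these data alone, compound 1 and compound 4 differ in two places, so it remains open whether the ethoxycarbonyl group of compound 1 or the methylcarbamoyl group of compound 4 serves better on an otherwise identical core. The compounds shown also leave open how a larger group on the same carbonyl carbon, such as dimethylamino, ethylamino or a longer chain ending in an amine or a carboxylic acid, would compare with methylamino.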